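The compounds below may be only part of what the source reports. "The series", "measured", "known", "first", "only" and "open" are said of these compounds alone.

The measured compounds are:

compound 1 `O=C(Nc1ccccc1Br)N[C@@H]1CCN(c2cccc(F)c2)C1` — 7.8
compound 2 `Cc1cccc2c1CCN2CCNC(=O)Nc1ccccc1Br` — 7.4
compound 3 `O=C(Nc1ccccc1Br)N[C@@H]1CCN(c2cccc(C(F)(F)F)n2)C1` — 7.2

Three compounds have been run in a functional assay for antagonist activity at transient receptor potential cation channel subfamily V member 1 (Rattus norvegicus), read by FLIPR (a lower number here means a less potent compound, a higher number a more potent compound, by a factor of ten per unit of this negative logarithm), all sharing the bromophenyl urea. Compound 1 `O=C(Nc1ccccc1Br)N[C@@H]1CCN(c2cccc(F)c2)C1` gives 7.8 in this assay, the highest of the three numbers. Compound 2 `Cc1cccc2c1CCN2CCNC(=O)Nc1ccccc1Br` gives 7.4 in this assay, a number lower than compound 1 by more than the usual scatter. Compound 3 `O=C(Nc1ccccc1Br)N[C@@H]1CCN(c2cccc(C(F)(F)F)n2)C1` gives 7.2 in this assay, lower again and the furthest from compound 1, also beyond the scatter. No two of these compounds differ in only one place, so no single change has yet been measured on its own.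

Compound 4 `Cc1ccc(N2CC[C@@H](NC(=O)Nc3ccccc3Br)C2)cc1F` has not yet been measured in this assay. It differs from compound 1 as follows: methyl in place of hydrogen on an aromatic carbon. The change is small in count, a single carbon added on the ring that carries the fluoro group. The three measured compounds do not show what a methyl at this position does, so the account here can only expect a step of modest size, most likely within the scatter, with no clear direction. Compound 4 is therefore estimated at 7.9 in this assay, in the range 7.4 to 8.4, which means an expected step of a number 0.10 log units higher from compound 1 to compound 4 (within the scatter).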

Compound 4, negative logarithm of the antagonist equilibrium constant in the transient receptor potential cation channel subfamily V member 1 assay: 8.3
Compound 4: the middle estimate sits 0.40 log units below what was measured, within the range that was stated.
By their numbers in the transient receptor potential cation channel subfamily V member 1 assay, from the lowest: compounds 3 and 2 (each within the scatter of the next); then compound 1; then compound 4.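

Methyl in place of hydrogen on an aromatic carbon, which turns 3-fluorophenyl into 3-fluoro-4-methylphenyl, is the first single change measured on its own in this set, and in the transient receptor potential cation channel subfamily V member 1 assay it gives a number 0.50 log units higher from compound 1 to compound 4 (beyond the scatter). A methyl at this place, ortho to a fluoro group and para to a large group, is therefore accepted, and the number rises beyond the scatter rather than staying level. On solubility, in a physicochemical assay for solubility (a lower number here means a less soluble compound, a higher number a more soluble compound), compound 1 gives < 100 ug/mL, a limit of the assay, and in a separate reading in the physicochemical assay compound 4 gives < 100 ug/mL, which is also a limit of the assay.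

The step between these two solubility readings cannot be read, because neither is a number: the limit of < 100 ug/mL in the physicochemical assay, at which 2 of the 2 values shown sit. The compounds shown also leave open whether the rise is special to methyl or would also come with an ethyl, a methoxy or an amine on the same carbon, and whether it would survive without the fluoro group.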